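The source may hold more compounds than are shown below. What is called first, only, known or untested is meant among the compounds shown, and "the series" means these compounds.

Measured in a physicochemical assay for solubility, read by spectrophotometry, using the shake flask method, with a stated time of 2 days, at pH 6.5; on this read-out higher numbers stand for higher solubility and lower numbers for lower solubility:
- compound 1 `O=C(O)COc1ccc2nc(-c3cn(-c4ccc(O)cc4)nn3)ccc2c1`: 365 ug/mL
- compound 2 `Oc1ccc(-n2cc(-c3ccc4ccccc4n3)nn2)cc1`: 2.2 ug/mL
- compound 3 `NCCOCCOc1ccc2nc(-c3cn(-c4ccc(O)c(F)c4)nn3)ccc2c1`: 9.1 ug/mL

Of these three, compound 2 stands lowest, at 2.2 ug/mL. Compound 4 `NCCOc1ccc2nc(-c3cn(-c4ccc(O)cc4)nn3)ccc2c1` departs from it by one change: 2-aminoethoxy in place of hydrogen on an aromatic carbon. Within the data shown here, the one measured step that bears on this is large, a 170-fold lower number from compound 1 to compound 2 (2.22 log units; beyond the scatter), where hydrogen takes the place of carboxymethoxy on an aromatic carbon. Read in reverse, it points to a higher number in this assay when a chain enters. Compound 4 differs from compound 3 in more than one place. Compound 3 gives 9.1 ug/mL, so a moderate rise rather than a rise of the full size is expected. The expected step is a 6.8-fold higher number from compound 2 to compound 4 (0.83 log units; beyond the scatter), beyond the scatter. For compound 4 the estimated value is 15 ug/mL, with an expected range from 5 ug/mL to 60 ug/mL.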

Compound 4, solubility: 3.7 ug/mL
Compound 4: middle estimate off by 4.1-fold (0.61 log units), on the high side; measured number outside the range, below it.
By their numbers in this assay, from the lowest: compounds 2 and 4 (each within the scatter of the next); then compound 3; then compound 1.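

In this assay, 2-aminoethoxy in place of hydrogen on this aromatic carbon gives a step within the scatter (a 1.7-fold higher number from compound 2 to compound 4 (0.23 log units; within the scatter)), so at this position a chain as such does not carry the large difference seen with carboxymethoxy. With the chain kept in place, aminomethyl in place of carboxy gives a large step (a 99-fold lower number from compound 1 to compound 4 (1.99 log units; beyond the scatter)), which ties the high number of compound 1 to the carboxy end of its chain rather than to the chain alone. Nothing measured here gives a reason for this. From the compounds shown here alone, whether a chain ending in a hydroxyl or an amide would stand nearer compound 1 or compound 2 remains open.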